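The compounds below may be only part of what the source reports. "The series", "measured", "known", "first", "only" and "open" are said of these compounds alone.

Going by the values given here, in a functional assay on NCI-H1975 cells (Homo sapiens) for antiproliferative activity, read by CCK-8 assay, with a stated time of 72 h (on this read-out higher numbers stand for weaker inhibition of growth and lower numbers for stronger inhibition of growth), compound 1 (`CCC1C(=O)N(C)c2cnc(-n3ccc4cc(C(=O)NC(C)C)ccc43)nc2N1c1ccn(C)n1`) gives 12200 nM and stands highest of the three numbers measured so far. In this assay compound 2 (`CCCCNC(=O)c1ccc2c(ccn2-c2ncc3c(n2)N(C2CCCC2)[C@H](CC)C(=O)N3C)c1`) gives 990 nM and compound 3 (`CCNC(=O)c1ccc2c(ccn2-c2ncc3c(n2)N(C2CCCC2)[C@H](CC)C(=O)N3C)c1`) gives 882 nM, both well under compound 1. Compound 4 (`CCC1C(=O)N(C)c2cnc(-n3ccc4cc(C(=O)NC5CCCC5)ccc43)nc2N1c1ccn(C)n1`) keeps the rest of compound 1 and changes one group, with cyclopentyl in place of isopropyl on an amide-type nitrogen. Among the compounds with values here, the one measured step that touches the group on this amide is a 1.1-fold lower number from compound 2 to compound 3 (0.05 log units; within the scatter), and it lies within the scatter. Within the data shown here, that step is only a loose guide, since those two compounds differ from compound 1 elsewhere in the structure and no measured pair tests a ring on that nitrogen. On this evidence, no change beyond the scatter is expected in this assay. The estimated step is a 1.2-fold lower number from compound 1 to compound 4 (0.09 log units; within the scatter), which stays within that expectation. Compound 4 is estimated at 10000 nM (expected range 4000 nM to 25000 nM).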

Compound 4, concentration for 50% growth inhibition: "not active" (no number reported)
For compound 4 the study gives words and no number; the estimate stays without a comparison.
By their numbers in this assay, from the lowest: compounds 3 and 2 (each within the scatter of the next); then compound 1.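

In this assay, going by these compounds alone, compound 4 is reported only as "not active", so no step from compound 1 to compound 4 can be read. The compounds shown leave open how far cyclopentyl in place of isopropyl shifts growth inhibition. No further evidence bears on this result.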